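Chain length and toxicity to MRC5 cells

The source may hold more compounds than are shown below. What is called first, only, known or untested is meant among the compounds shown, and "the series" means these compounds.

Compound 1 `CCCC(=O)OCCc1ccc(O)c(O)c1` gives 71500 nM
Compound 2 `CCCCCC(=O)OCCc1ccc(O)cc1` gives 166000 nM
Compound 3 `CCCCCCCCCCCC(=O)OCCc1ccc(O)cc1` gives 67200 nM

In a toxicity assay on MRC5 cells (Homo sapiens) for inhibition, read by MTT assay, with a stated time of 72 h (on this read-out lower numbers stand for stronger inhibition and higher numbers for weaker inhibition), compound 3 at 67200 nM stands within the scatter of compound 1 at 71500 nM. Compound 2 gives 166000 nM, and its gap to compound 3 lies beyond the scatter. Compound 4 `CCCCCCCCCC(=O)OCCc1ccc(O)cc1` arises from compound 3 by hydrogen in place of ethyl on a saturated chain carbon, nine bonds along the chain from a carbonyl carbon with hydrogen in place of ethyl. Among the compounds with values here, the one measured step on this chain is a 2.5-fold lower number from compound 2 to compound 3 (0.39 log units; beyond the scatter) for hexyl in place of hydrogen, and it was modest. Losing only ethyl should reverse part of that change, so a small move to a higher number is expected, probably within the scatter. The expected step is a 1.3-fold higher number from compound 3 to compound 4 (0.13 log units; within the scatter) by this estimate. Compound 4 is estimated at 90000 nM with 50000 nM to 165000 nM as its likely range.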

Compound 4, half-maximal inhibitory concentration: 172000 nM
For compound 4 the middle estimate is 1.9-fold (0.28 log units) below the measured one; measured number above the stated range.
By their numbers in this assay, from the lowest: compounds 3 and 1 (each within the scatter of the next); then compounds 2 and 4 (each within the scatter of the next).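

In this assay, hydrogen in place of ethyl on a saturated chain carbon, nine bonds along the chain from a carbonyl carbon, gives a 2.6-fold higher number from compound 3 to compound 4 (0.41 log units; beyond the scatter), so this small change at the far end of the chain matters beyond the scatter. Butyl in place of hydrogen, five bonds along the chain from a carbonyl carbon, gives only a 1.0-fold higher number from compound 2 to compound 4 (0.02 log units; within the scatter), so the three chain compounds show no gradual trend with length. The data offered here give no explanation for this.

As far as these compounds go, whether a longer chain would hold or lose the number of compound 3 stays open. So does the effect of an amine or a carboxylic acid at the chain end.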